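The source may report more compounds than this note shows. Statements on the series, on what has been measured and on what is new or still open speak of the compounds shown alone.

Series notes. Compound 1 `Cn1c(=O)c(=O)n(C2CCCC2)c2nc(N/N=C/c3ccc(F)c(Cl)c3)ncc21` is the reference point. Among the compounds with values here, in a functional assay on A549 cells (Homo sapiens) for antiproliferative activity, read by MTT assay (a lower number here means a stronger inhibitor, a higher number a weaker inhibitor), compound 1 gives 9410 nM, the lowest of the three numbers so far. Compound 3 `Cc1cc(C)c(/C=N/Nc2ncc3c(n2)n(C2CCCC2)c(=O)c(=O)n3C)c(C)c1` gives 12000 nM; the step of a 1.3-fold higher number from compound 1 to compound 3 (0.11 log units; within the scatter) stays within the scatter, so compounds 1 and 3 cannot be told apart. Compound 2 `Cn1c(=O)c(=O)n(C2CCCC2)c2nc(N/N=C/c3ccc(S(C)(=O)=O)cc3)ncc21` gives 84500 nM, and the step of a 9.0-fold higher number from compound 1 to compound 2 (0.95 log units; beyond the scatter) is the only one beyond the scatter; a 7.0-fold lower number from compound 2 to compound 3 (0.85 log units; beyond the scatter) is the same gap seen from compound 2.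

Compound 4 `Cn1c(=O)c(=O)n(C2CCCC2)c2nc(N/N=C/c3ccc(F)cc3Cl)ncc21` has not been measured. It differs from compound 1 in this way: 2-chloro-4-fluorophenyl in place of 3-chloro-4-fluorophenyl on a carbon with a double bond to nitrogen. Within the data shown here, two measured steps concern exchanges of the aryl group on the same carbon; neither repeats this one. The step of a 1.3-fold higher number from compound 1 to compound 3 (0.11 log units; within the scatter) shows that a changed substitution pattern on the phenyl need not move the number, while the step of a 9.0-fold higher number from compound 1 to compound 2 (0.95 log units; beyond the scatter) shows that a larger move appeared only when a methylsulfonyl group entered. Compound 4 carries no such group, so no step beyond the scatter is expected, with a slight lean toward a higher number since compound 1 at 9410 nM is already the lowest seen. Compound 4 is therefore expected at 12000 nM, between 4000 nM and 36000 nM. The expected step is a 1.3-fold higher number from compound 1 to compound 4 (0.11 log units; within the scatter).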

Compound 4, half-maximal inhibitory concentration: 11000 nM
Beside the measured number, compound 4's estimate is 1.1-fold (0.04 log units) above it, within the range that was stated.
By their numbers in this assay, from the lowest: compounds 1, 4 and 3 (each within the scatter of the next); then compound 2.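

Within the data shown here, compound 4 is the first change on this carbon that keeps the atoms of the aryl group and only joins them differently. In this assay it gives a 1.2-fold higher number from compound 1 to compound 4 (0.07 log units; within the scatter), so 3-chloro-4-fluorophenyl and 2-chloro-4-fluorophenyl cannot be told apart in this series. With a 1.1-fold lower number from compound 3 to compound 4 (0.04 log units; within the scatter) as well, the three aryl groups of compounds 1, 3 and 4 form one group of numbers despite their different substitution, and compound 2 is the only one outside it, as a 7.7-fold lower number from compound 2 to compound 4 (0.89 log units; beyond the scatter) confirms from the side of the new compound. Nothing available bears on why these numbers fall together or why the 4-(methylsulfonyl)phenyl compound stands apart.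

On these data alone, it remains open whether the separation of compound 2 belongs to the methylsulfonyl group alone or would also appear with a nitrile, a carboxylic acid or an amine on the phenyl ring. The compounds shown also leave open how the number responds at other places on the shared core, for instance with a longer chain in place of the cyclopentyl group.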